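Swapping an aryl group on a thiazole amide pair

The compounds below may be only part of what the source reports. "The series", "measured", "known", "first", "only" and "open" are said of these compounds alone.

Four compounds share one core. Compound 1 `CN(C(=O)NC(=O)c1ccccc1F)c1nc(C(F)(F)F)c(C(=O)N/N=C/c2cc(C(F)(F)F)cc(C(F)(F)F)c2)s1` gives 4.23 ug/mL in a functional assay on BCG823 cells (Homo sapiens) for inhibition, read by MTT assay, with a stated time of 72 h; on this read-out higher numbers stand for weaker inhibition and lower numbers for stronger inhibition. Compound 2 `CN(C(=O)NC(=O)c1cccc(C(F)(F)F)c1)c1nc(C(F)(F)F)c(C(=O)N/N=C/c2cc(C(F)(F)F)cc(C(F)(F)F)c2)s1` carries 3-(trifluoromethyl)phenyl in place of 2-fluorophenyl on a carbonyl carbon and gives 5.23 ug/mL in this assay, a step of a 1.2-fold higher number from compound 1 to compound 2 (0.09 log units; within the scatter). Compound 3 `CN(C(=O)NC(=O)c1ccccc1F)c1nc(C(F)(F)F)c(C(=O)N/N=C/c2cccc(C(F)(F)F)c2)s1` has a different core, set apart from compound 1 by hydrogen in place of trifluoromethyl on an aromatic carbon; in this assay compound 3 gives 16.3 ug/mL, a step of a 3.9-fold higher number from compound 1 to compound 3 (0.59 log units; beyond the scatter). Compound 4 `CN(C(=O)NC(=O)c1cccc(C(F)(F)F)c1)c1nc(C(F)(F)F)c(C(=O)N/N=C/c2cccc(C(F)(F)F)c2)s1` has not been measured. It differs from compound 3 by 3-(trifluoromethyl)phenyl in place of 2-fluorophenyl on a carbonyl carbon, at the same place as the change from compound 1 to compound 2, so it is the same change on the other core. Compound 4 is expected to show a 1.2-fold higher number from compound 3 to compound 4 (0.07 log units; within the scatter) because the same change earlier gave a 1.2-fold higher number from compound 1 to compound 2 (0.09 log units; within the scatter). The estimate for compound 4 is 19 ug/mL, most likely between 10 ug/mL and 38 ug/mL.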

Compound 4, half-maximal inhibitory concentration: 4.6 ug/mL
Compound 4: the middle estimate sits 4.1-fold (0.62 log units) above what was measured; measured number below the stated range.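

In this assay, 3-(trifluoromethyl)phenyl in place of 2-fluorophenyl gives a 3.5-fold lower number from compound 3 to compound 4 (0.55 log units; beyond the scatter), so this change does not carry over unchanged from one core to the other: the same change on two cores in this assay, a 1.2-fold higher number (0.09 log units; within the scatter) from compound 1 to compound 2 and a 3.5-fold lower number (0.55 log units; beyond the scatter) from compound 3 to compound 4, 4.4-fold (0.64 log units) apart, beyond the scatter of two such steps. Hydrogen in place of trifluoromethyl on an aromatic carbon gives a 1.1-fold lower number from compound 2 to compound 4 (0.06 log units; within the scatter), and this change also depends on its partner group: the same change on two cores in this assay, a 3.9-fold higher number (0.59 log units; beyond the scatter) from compound 1 to compound 3 and a 1.1-fold lower number (0.06 log units; within the scatter) from compound 2 to compound 4, 4.4-fold (0.64 log units) apart, beyond the scatter of two such steps. These four compounds show that the two changes do not act independently here, but they do not show why, or whether other groups would behave the same way.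

As far as these compounds go, it remains open whether a chlorophenyl or a pyridine ring on the same carbonyl carbon would respond in the same way on both cores.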